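From a diethylamino side chain to a hydroxymethyl one

The source may report more compounds than this note shows. Statements on the series, on what has been measured and on what is new or still open speak of the compounds shown alone.

For the measured compounds named here, in a functional assay on PC-3 cells (Homo sapiens) for antiproliferative activity, read by MTT assay, with a stated time of 24 h (a higher number here means a weaker inhibitor, a lower number a stronger inhibitor), compound 2 `CCN(CC)CCNC(=O)c1ccc(C(CC)(CC)c2ccc(OCS(=O)(=O)c3ccccc3)c(C)c2)n1CC` gives 7130 nM as the lower of the two exact numbers so far. Compound 3 `CCn1c(C(=O)NCCO)ccc1C(CC)(CC)c1ccc(OCS(=O)(=O)c2ccccc2)c(C)c1` gives 17700 nM as the other. Compound 1 `CCn1c(C(=O)N[C@H](C)C(=O)OC)ccc1C(CC)(CC)c1ccc(OCS(=O)(=O)c2ccccc2)c(C)c1` gives > 50000 nM which is a limit of the assay and not a number. Compound 4 `CCn1c(C(=O)N[C@@H](CO)C(C)C)ccc1C(CC)(CC)c1ccc(OCS(=O)(=O)c2ccccc2)c(C)c1` differs from compound 2 on the amide-type nitrogen (1-(hydroxymethyl)-2-methylpropyl in place of 2-(diethylamino)ethyl on an amide-type nitrogen). The closest guide is compound 3, which also trades diethylamino for a chain with a hydroxy group (a 2.5-fold higher number from compound 2 to compound 3 (0.39 log units; beyond the scatter)). The ester chain also gave a higher number than the diethylamino chain (an at least 7.0-fold lower number from compound 1 to compound 2 (0.84 log units; beyond the scatter)). A modest rise is therefore expected (a 2.8-fold higher number from compound 2 to compound 4 (0.45 log units; beyond the scatter)), meaning a somewhat weaker inhibitor. Compound 4 is estimated at 20000 nM within an expected range of 8000 nM to 50000 nM for this assay.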

Compound 4, half-maximal inhibitory concentration: 10600 nM
For compound 4 the middle estimate is 1.9-fold (0.28 log units) above the measured one; measured number inside the range.
By their numbers in this assay, from the lowest: compounds 2, 4 and 3 (each within the scatter of the next, the first and the last beyond it). At a limit, above all of these: compound 1.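

Replacing 2-(diethylamino)ethyl with 1-(hydroxymethyl)-2-methylpropyl gives a 1.5-fold higher number from compound 2 to compound 4 (0.17 log units; within the scatter), so on this amide-type nitrogen a number of this size does not depend on the diethylamino group. Adding isopropyl to the chain of compound 3 gives a 1.7-fold lower number from compound 3 to compound 4 (0.22 log units; within the scatter), so this branch changes little that can be told apart. The step from the ester chain, an at least 4.7-fold lower number from compound 1 to compound 4 (0.67 log units; beyond the scatter), rests on a limit and not a number: the limit of > 50000 nM in this assay, at which 1 of the 4 values shown sits.

Open, as far as these compounds go, is how a carboxylic acid or a cyclic amine such as morpholine would behave on this nitrogen. Open too, from the compounds shown here alone, is whether the mirror-image form of the 1-(hydroxymethyl)-2-methylpropyl chain gives a different number.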